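The source may report more compounds than this note shows. Statements on the series, on what has been measured and on what is new or still open speak of the compounds shown alone.

Measured so far:
compound 1 `CCCN(CC[C@H]1CC[C@H](NC(=O)/C=C/c2ccccc2OC)CC1)[C@H]1CCc2nc(N)sc2C1` – 8.1 nM
compound 2 `CCCN(CC[C@H]1CC[C@H](NC(=O)c2ccc(-c3noc(C)n3)cc2)CC1)[C@H]1CCc2nc(N)sc2C1` – 1.3 nM
compound 3 `CCCN(CC[C@H]1CC[C@H](NS(=O)(=O)c2ccccc2)CC1)[C@H]1CCc2nc(N)sc2C1` – 0.79 nM

These three compounds share the same core and differ only in the group attached to the ring nitrogen. In an assay on brain for displacement of a labelled ligand from D(3) dopamine receptor (Rattus norvegicus) (on this read-out lower numbers stand for stronger inhibition and higher numbers for weaker inhibition), compound 3 gives the lowest of the three numbers; compound 2 sits within the scatter of it, and compound 1 lies beyond the scatter above it. Compound 4 `CCCN(CC[C@H]1CC[C@H](NS(=O)(=O)c2ccc(Cl)nc2)CC1)[C@H]1CCc2nc(N)sc2C1` differs from compound 3 in one place: 6-chloropyridin-3-yl in place of phenyl on a sulfonyl sulfur.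

Among the compounds with values here, no measured step touches the sulfonyl group itself. Within the data shown here, the only step in the set, a 6.2-fold lower number from compound 1 to compound 2 (0.79 log units; beyond the scatter), swaps one aryl group for another on a carbonyl carbon and so lies at a different place; it shows that a change of the aryl group can move this read-out beyond the scatter, but it gives no direction for a change on a sulfonyl sulfur. The expectation for compound 4 is therefore a step of a 1.4-fold higher number from compound 3 to compound 4 (0.14 log units; within the scatter), most likely within the scatter. Compound 4 is estimated at 1.1 nM, with a range from 0.35 nM to 3.5 nM.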

Compound 4, inhibition constant: 0.63 nM
Compound 4: the middle estimate sits 1.7-fold (0.24 log units) above what was measured; measured number inside the range.
By their numbers in this assay, from the lowest: compounds 4, 3 and 2 (each within the scatter of the next, the first and the last beyond it); then compound 1.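

Within the data shown here, this is the first measured change made directly on the sulfonyl sulfur. In this assay the exchange of phenyl for 6-chloropyridin-3-yl gives a 1.3-fold lower number from compound 3 to compound 4 (0.10 log units; within the scatter) and so shows that a ring with a ring nitrogen, a chlorine and one more hydrogen-bond acceptor reads much like the plain phenyl ring at this place. Nothing measured here explains why the two rings read alike.

Both changes arrive together in compound 4, so the share of the ring nitrogen and that of the chlorine cannot be told apart; a pyridin-3-yl group without chlorine, or a phenyl ring carrying chlorine, would separate them. Also open, as far as these compounds go, is how far this place accepts other groups, such as a methyl group, a longer alkyl chain, or a ring bearing an amine or a carboxylic acid.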